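A few compounds are considered here, and "the series" means these few. Any claim that something is new, unique, unknown or untested is made for them only; others in the source may bear on it.

Working notes on the series. Among the measured compounds shown here, compound 1 `COc1cc(O)c(C(=O)O)c(C=Cc2ccc3ccccc3c2)c1` is the one fully quantified member: in an ADME assay on HepG2 cells (Homo sapiens) for cytotoxicity, read by resazurin assay, with a stated time of 24 h (on this read-out higher numbers stand for lower toxicity in this test and lower numbers for higher toxicity in this test), compound 1 gives 79000 nM. Compound 2 `O=C(O)c1c(O)cccc1CCc1ccc2ccccc2c1` is the saturated-linker analogue. In this assay compound 2 reaches only a limit of the assay, > 100000 nM, so where compound 2 stands is known just as the limit of > 100000 nM in this assay, at which 1 of the 2 values shown sits. Compound 3 `O=C(O)c1c(O)cc(Cl)cc1CCc1ccc2ccccc2c1` carries chloro in place of hydrogen on an aromatic carbon. For the measured compounds named here, no measured pair here shows a change of this kind, so the step expected is an at least 1.1-fold lower number from compound 2 to compound 3 (0.04 log units; that floor lies within the scatter), nothing beyond the scatter in either direction. Compound 3 is therefore estimated at 90000 nM, with a range of 40000 nM to 200000 nM, most likely reported once more only as a limit.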

Compound 3, half-maximal cytotoxic concentration: 35000 nM
Compound 3: middle estimate off by 2.6-fold (0.41 log units), on the high side; the measured number lies below the stated range.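

In this assay chloro in place of hydrogen on an aromatic carbon, para to a carboxy group, gives an at least 2.8-fold lower number from compound 2 to compound 3 (0.45 log units; beyond the scatter) and so shows that this position can change the read-out on the saturated-linker core. The size of this step remains a minimum, because compound 2 stands only at a limit of the assay: the limit of > 100000 nM in this assay, at which 1 of the 3 values shown sits.

Whether the shift is specific to chloro remains open, since no fluoro, bromo or amine group at this carbon is among the compounds shown. Going by these compounds, whether chloro acts alike with an unsaturated linker also remains open.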